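The compounds below may be only part of what the source reports. "The series", "measured", "known", "first", "only" and "open" are said of these compounds alone.

Compound 2 `COc1cc(Cl)cc(-c2nn(-c3cccc(NC(=O)Nc4cccc(C(F)(F)F)c4)c3)cc2-c2ccncc2)c1` and compound 1 `COc1cc(Cl)cc(-c2nn(-c3cccc(NC(=O)Nc4ccc(Cl)c(Cl)c4)c3)cc2-c2ccncc2)c1` share one core and differ only in the group on the urea. In a functional assay on SF-295 cells (Homo sapiens) for inhibition, read by sulforhodamine B assay, with a stated time of 48 h, tested at 0.01 uM (on this read-out higher numbers stand for a weaker effect at the one concentration tested and lower numbers for a stronger effect), compound 2 gives 94%, and compound 1 gives 87%; the two numbers lie together, as the step of a number 7 percentage points higher from compound 1 to compound 2 (within the scatter) shows. Compound 3 `COc1cc(Cl)cc(-c2nn(-c3cccc(NC(=O)c4cccc(C(F)(F)F)c4)c3)cc2-c2ccncc2)c1` is the unmeasured partner: 3-(trifluoromethyl)phenyl in place of (3-(trifluoromethyl)phenyl)amino on a carbonyl carbon. Going by the values given here, no measured step touches this position; the one step known, from compound 1 to compound 2, changed the outer aromatic group and stayed within the scatter. A step of about a number 2 percentage points lower from compound 2 to compound 3 (within the scatter) is therefore expected, none beyond the scatter. Compound 3 is estimated at 92%, between 72% and 108%.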

Compound 3, a percentage reported as activity, at one concentration (the size of the read-out at that concentration, not a potency): 98%
Estimate against measurement, compound 3: 6 percentage points below; the range from low to high includes it.
By their numbers in this assay, from the lowest: compounds 1, 2 and 3 (each within the scatter of the next, the first and the last beyond it).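

In this assay, the change of the urea to an amide, which takes away the nitrogen and its hydrogen-bond donor, gives a number 4 percentage points higher from compound 2 to compound 3 (within the scatter), so this position tolerates the loss of that nitrogen at this one concentration. The step of a number 11 percentage points higher from compound 1 to compound 3 (beyond the scatter) is the only one beyond the scatter, but it changes the outer aromatic group as well as the link, so it cannot be assigned to either change alone. Nothing available explains these numbers. From the compounds shown here alone, how a sulfonamide link or a cyclohexyl group in place of the outer aromatic ring would read remains open. All the numbers come from a single concentration and show only the size of the effect there, so how strong the effect of these compounds would be at other concentrations also remains open.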